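A few compounds are considered here, and "the series" means these few. Any claim that something is new, unique, unknown or untested is made for them only; others in the source may bear on it.

Measured compounds:
Compound 1 `CNCc1cc(-c2ccccc2)n(S(=O)(=O)c2ccc(C)cc2)c1` gives 66% in a functional assay on the whole organism (strain Jcl:SD) for inhibition, with Rattus norvegicus as the target, with stated times of 3 min and 3 h, at a dose of 1 mg/kg by the intravenous route; a lower number here means less inhibition, a higher number more inhibition at the dose given (going by the name of the read-out).
Compound 2 `CNCc1cc(-c2cccnc2C#N)n(S(=O)(=O)c2ccccc2)c1` gives 99% in this assay.
Compound 3 `CNCc1cc(-c2ccccc2C)n(S(=O)(=O)c2ccc(C)cc2)c1` gives 92% in this assay.

Compound 3 stands second highest of the three numbers. Its nearest neighbour is compound 2, whose value lies within the scatter of it, so no order between the two can be read. Compound 1 lies furthest away, and the one step that is shown, a number 26 percentage points higher from compound 1 to compound 3 (beyond the scatter), is beyond the scatter: a methyl in place of hydrogen on an aromatic carbon brings a modest rise.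

Compound 4 `CNCc1cc(-c2ccccc2C(F)(F)F)n(S(=O)(=O)c2ccc(C)cc2)c1` is not yet measured. It differs from compound 3 in one place: trifluoromethyl in place of methyl on an aromatic carbon. For the measured compounds named here, no measured step covers a trifluoromethyl in place of methyl; the only step that touches this position is the one from compound 1 to compound 3, which shows a higher number in this assay with methyl than with hydrogen. Compound 3 already sits close to the top of the scale, so little room remains upward. The author therefore expects a step of about a number 2 percentage points lower from compound 3 to compound 4 (within the scatter), within the scatter, and estimates compound 4 at 90%, between 72% and 99%.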

Compound 4, a percentage reported as inhibition, in the whole organism at one dose (the size of the read-out at that dose, not a potency) in the Rattus norvegicus assay: 86%
Estimate against measurement, compound 4: 4 percentage points above, within the range that was stated.
By their numbers in the Rattus norvegicus assay, from the lowest: compound 1; then compounds 4, 3 and 2 (each within the scatter of the next, the first and the last beyond it).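

In the Rattus norvegicus assay, trifluoromethyl and methyl at this position cannot be told apart, with a number 6 percentage points lower from compound 3 to compound 4 (within the scatter), yet the gain over hydrogen is not confined to methyl, since the step is a number 20 percentage points higher from compound 1 to compound 4 (beyond the scatter). In a physicochemical assay for lipophilicity, read by HPLC, at pH 7.4 (a higher number here means a more lipophilic compound, a lower number a more polar compound), compound 3 gives 2.12 and compound 4 gives 1.94, which is a number 0.18 log units lower from compound 3 to compound 4 (within the scatter), so this exchange moves neither read-out beyond the scatter. Nothing available here accounts for the higher numbers of either group over hydrogen.

As far as these compounds go, whether a chlorine atom, a methoxy group or an amine on this aromatic carbon would also keep the number high remains open. So does whether the same holds for the core of compound 2, which differs from these compounds in more than one place.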